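Terminal ring swap: compound 3 to compound 4

This account rests on a few compounds, and the source may have more. Where it says the series, first, only, none or still open, it means among the compounds named here.

Measured so far:
compound 1 `CCC(C)(C)Cc1c[nH]c(CCc2ccc(-n3cccn3)cc2)n1`: 135 nM
compound 2 `CCC(C)(C)Cc1c[nH]c(CCc2ccc(-c3cccc(C#N)n3)cc2)n1`: 193 nM
compound 3 `CCC(C)(C)Cc1c[nH]c(CCc2ccc(-c3csnn3)cc2)n1`: 538 nM

In a functional assay on HEK293 cells for agonist activity at Bombesin receptor subtype-3 (Homo sapiens), read by luminescence and calcium flux, with a stated time of 10 min (a lower number here means that less compound is needed, a higher number that more compound is needed for the effect), compound 3 stands highest of the three numbers; the nearest is compound 2, as seen in a 2.8-fold higher number from compound 2 to compound 3 (0.45 log units; beyond the scatter), and the furthest is compound 1, as seen in a 4.0-fold higher number from compound 1 to compound 3 (0.60 log units; beyond the scatter). Compound 4 `CCC(C)(C)Cc1c[nH]c(CCc2ccc(-c3cccnc3)cc2)n1` carries pyridin-3-yl in place of 1,2,3-thiadiazol-4-yl on an aromatic carbon. The step from compound 2 to compound 3 bears most directly on this change: compound 2 also carries a six-membered ring with one hetero atom, and a 1.4-fold higher number from compound 1 to compound 2 (0.16 log units; within the scatter) shows that two such terminal groups sit close together. A lower number in this assay is therefore expected, roughly undoing that step: a 2.7-fold lower number from compound 3 to compound 4 (0.43 log units; beyond the scatter). Compound 4 is estimated at 200 nM, with a range of 90 nM to 450 nM.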

Compound 4, half-maximal effective concentration: 131 nM
Estimate against measurement, compound 4: 1.5-fold (0.18 log units) above, within the range that was stated.
By their numbers in this assay, from the lowest: compounds 4, 1 and 2 (each within the scatter of the next); then compound 3.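

At this place, para to a large group, pyridin-3-yl in place of 1,2,3-thiadiazol-4-yl gives a 4.1-fold lower number from compound 3 to compound 4 (0.61 log units; beyond the scatter) in this assay, leaving compound 3 alone among the terminal rings shown. Compound 4 sits level with the other two (a 1.5-fold lower number from compound 2 to compound 4 (0.17 log units; within the scatter); a 1.0-fold lower number from compound 1 to compound 4 (0.01 log units; within the scatter)), and a five-membered ring as such does not go with the higher number, since compound 1 carries one. Nothing measured here explains these differences.

Open, on these data alone, is whether an amine or a carboxylic acid on the pyridin-3-yl ring keeps this level, and whether other five-membered rings with 3 hetero atoms follow compound 3.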